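Ring exchange at the hydrazone end of the shared core

A few compounds are considered here, and "the series" means these few. Any claim that something is new, unique, unknown or untested is made for them only; others in the source may bear on it.

Measured so far in an ADME assay on HT-29 cells (Homo sapiens) for inhibition, read by MTT assay, with a stated time of 72 h; on this read-out higher numbers stand for weaker inhibition and lower numbers for stronger inhibition:
compound 1 `C=CC(=O)Nc1cccc(Nc2nc(N/N=C/c3ccccc3F)ncc2Cl)c1` gives 3500 nM
compound 2 `C=CC(=O)Nc1cccc(Nc2nc(N/N=C(\C)c3ccc(C)cc3)ncc2Cl)c1` gives 3210 nM

Compound 2 and compound 1 give numbers within the scatter of each other in this assay, so neither stands apart. Compound 3 `C=CC(=O)Nc1cccc(Nc2nc(N/N=C(\C)c3ccncc3)ncc2Cl)c1` differs from compound 2 by pyridin-4-yl in place of 4-methylphenyl on a carbon with a double bond to nitrogen. Going by the values given here, the only measured step on this side of the shared core is a 1.1-fold lower number from compound 1 to compound 2 (0.04 log units; within the scatter), an exchange of one ring for another that stayed within the scatter. Among the compounds with values here, no measured pair shows a ring carbon replaced by a ring nitrogen. A step within the scatter is expected because a 1.1-fold lower number from compound 1 to compound 2 (0.04 log units; within the scatter) gave none beyond it, so compound 3 is expected at a 1.0-fold higher number from compound 2 to compound 3 (0.01 log units; within the scatter). Compound 3 is estimated at 3300 nM, range 1600 nM to 7000 nM.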

Compound 3, half-maximal inhibitory concentration: 12800 nM
Compound 3: middle estimate off by 3.9-fold (0.59 log units), on the low side; measured number above the stated range.
By their numbers in this assay, from the lowest: compounds 2 and 1 (each within the scatter of the next); then compound 3.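

In this assay, going by these compounds alone, the ring on the carbon with a double bond to nitrogen does matter: pyridin-4-yl in place of 4-methylphenyl gives a 4.0-fold higher number from compound 2 to compound 3 (0.60 log units; beyond the scatter) and is the first exchange here to go beyond the scatter. Compound 3 also stands apart from the fluorinated ring, with a 3.7-fold higher number from compound 1 to compound 3 (0.56 log units; beyond the scatter) as the step, so at this end of the shared core only the ring with a hetero atom separates from the others. Nothing measured here accounts for this shift.

As far as these compounds go, whether the higher number goes with the ring nitrogen or with the lost methyl group stays open. Unsubstituted phenyl or pyridin-3-yl on the same carbon would separate the two.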